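Thioether Amide with a Diene Chain in Place of Hydroxy-ene

A few compounds are considered here, and "the series" means these few. Any claim that something is new, unique, unknown or untested is made for them only; others in the source may bear on it.

Measured compounds:
compound 1, `CCCCCCCCCCCCCCCC(=O)N/N=C/c1ccc(O)c(OC)c1`, 6000 nM in an assay on HEK293 cells for antagonist activity at transient receptor potential cation channel subfamily V member 2 (Rattus norvegicus), read by fluorescence and calcium flux, with a stated time of 5 min; on this read-out higher numbers stand for weaker inhibition and lower numbers for stronger inhibition
compound 2, `CCCCCC[C@@H](O)C/C=C\CCCCCCCCSCCC(=O)NCc1ccc(O)c(OC)c1`, result "not determined" (no result reported) in this assay

Compound 2 stands with no number of its own: in this assay compound 2 is recorded as "not determined" (no result reported), so it cannot be placed against compound 1, whose value in this assay is 6000 nM. Compound 3, `CCCCC/C=C\C/C=C\CCCCCCCCSCCC(=O)NCc1ccc(O)c(OC)c1`, is built from compound 2 by the change (hept-1-en-1-yl in place of 1-hydroxyheptyl on a saturated chain carbon bound to a double-bonded chain carbon). For the measured compounds named here, no measured pair shows what this change does to the read-out, so the direction of the step in this assay is open; with only compound 1 as a point of reference, a result in the same broad region is the plainest expectation, and a step in either direction beyond the scatter would not be surprising. Compound 3 is therefore expected near 5000 nM, in a range from 800 nM to 30000 nM.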

Compound 3, half-maximal inhibitory concentration: 2800 nM
Estimate against measurement, compound 3: 1.8-fold (0.25 log units) above, and the stated range covers the measured number.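

No step can be read from this result, since compound 2 has no number in this assay and compound 3 at 2800 nM has no measured partner differing in one place. From the compounds shown here alone, what replacing 1-hydroxyheptyl with hept-1-en-1-yl does to the read-out stays open, and no supporting measurement bears on it.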